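Swapping a benzyl substituent in a cytotoxicity series

This account rests on a few compounds, and the source may have more. Where it says the series, first, only, none or still open, it means among the compounds named here.

Measured compounds:
compound 1 `Cc1cccc(CSc2cc(Cl)c(C)cc2S(=O)(=O)/N=C(\N)n2nccc2-c2ccccc2)c1`: 10000 nM
compound 2 `Cc1cc(S(=O)(=O)/N=C(\N)n2nccc2-c2ccccc2)c(SCc2cccc(C(F)(F)F)c2)cc1Cl`: 18000 nM
compound 3 `Cc1cc(-c2ccccc2)n(/C(N)=N/S(=O)(=O)c2cc(C)c(Cl)cc2SCc2ccccc2)n1`: 10000 nM

Of the compounds shown here, three sharing one core have been tested in an ADME assay on HaCaT cells (Homo sapiens) for cytotoxicity, read by MTT assay, with a stated time of 72 h; on this read-out higher numbers stand for weaker inhibition and lower numbers for stronger inhibition. Compound 1 `Cc1cccc(CSc2cc(Cl)c(C)cc2S(=O)(=O)/N=C(\N)n2nccc2-c2ccccc2)c1` gives 10000 nM, and compound 3 `Cc1cc(-c2ccccc2)n(/C(N)=N/S(=O)(=O)c2cc(C)c(Cl)cc2SCc2ccccc2)n1` gives 10000 nM, level with compound 1 at the digits shown; together they hold the lowest numbers of the three. Compound 2 `Cc1cc(S(=O)(=O)/N=C(\N)n2nccc2-c2ccccc2)c(SCc2cccc(C(F)(F)F)c2)cc1Cl` gives 18000 nM, which is the furthest from compound 1, yet the step of a 1.8-fold higher number from compound 1 to compound 2 (0.26 log units; within the scatter) stays within the scatter of this assay.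

Compound 4 `Cc1cc(S(=O)(=O)/N=C(\N)n2nccc2-c2ccccc2)c(SCc2ccccc2C(F)(F)F)cc1Cl` has not yet been measured. It differs from compound 1 in one place: 2-(trifluoromethyl)phenyl in place of 3-methylphenyl on a saturated chain carbon bound to a sulfur.

Going by the values given here, the only measured step that bears on this change is a 1.8-fold higher number from compound 1 to compound 2 (0.26 log units; within the scatter), where trifluoromethyl replaced methyl on an aromatic carbon and the number did not move beyond the scatter. Among the compounds with values here, the change to compound 4 also brings in a trifluoromethyl group on the benzyl ring, though at a different position of that ring, for which no measured pair exists. On this evidence no shift beyond the scatter is expected.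

Compound 4 is therefore estimated at 12000 nM, with a range of 6000 nM to 30000 nM, an expected step of a 1.2-fold higher number from compound 1 to compound 4 (0.08 log units; within the scatter).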

Compound 4, half-maximal inhibitory concentration: 20000 nM
Estimate against measurement, compound 4: 1.7-fold (0.22 log units) below, within the range that was stated.
By their numbers in this assay, from the lowest: compounds 1, 3, 2 and 4 (each within the scatter of the next).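

In this assay, placing 2-(trifluoromethyl)phenyl in place of 3-methylphenyl on a saturated chain carbon bound to a sulfur gives a 2.0-fold higher number from compound 1 to compound 4 (0.30 log units; within the scatter), so this larger change at the position, with its three fluorine atoms, still stays inside the scatter. Going by these compounds alone, the pair of compound 2 and compound 4 adds what the earlier compounds could not show, a direct comparison of two trifluoromethyl-bearing rings at this position: 2-(trifluoromethyl)phenyl in place of 3-(trifluoromethyl)phenyl gives a 1.1-fold higher number from compound 2 to compound 4 (0.05 log units; within the scatter), and on this read-out the two are not told apart. No measured evidence accompanies these results to account for them.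

Both steps keep to a ring of carbon only carrying trifluoromethyl or methyl, so the compounds shown leave open whether an amine or a carboxylic acid on that ring would move the number beyond the scatter. They also leave open whether a longer chain bound to the sulfur in place of the benzyl group would do so.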